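The source may hold more compounds than are shown below. What is called first, only, known or untested is meant among the compounds shown, and "the series" means these compounds.

Among the measured compounds shown here, compound 2 `COc1ccc(/C=C/C(=O)c2ccc(N)c(-c3ccc(F)cc3)c2)cc1OC` is, among the three compounds for which a number exists in a functional assay on A549 cells (Homo sapiens) for cytotoxicity, read by sulforhodamine B assay, with a stated time of 48 h (on this read-out higher numbers stand for weaker inhibition and lower numbers for stronger inhibition), the one with the lowest value: in this assay compound 2 gives 8630 nM. Its nearest neighbour is compound 3 `COc1ccc(/C=C/C(=O)c2cccc(-c3ccc(F)cc3)c2)cc1OC`, which in this assay gives 11800 nM, and the step from compound 2 to compound 3 is a 1.4-fold higher number from compound 2 to compound 3 (0.14 log units; within the scatter), so the two compounds cannot be told apart. For the measured compounds named here, the furthest is compound 1 `Nc1ccc(C(=O)/C=C/c2ccc(O)c(F)c2)cc1-c1ccc(F)cc1`, which in this assay gives 24500 nM; compound 1 carries a hydroxy and a fluoro where compound 2 carries two methoxy groups, and no single step links the two, so their values are only compared as they stand.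

Compound 4 `COc1ccc(/C=C/C(=O)c2ccc(N)c(-c3ccc(F)cc3)c2)cc1O` differs from compound 2 in one place: hydrogen in place of methyl on an oxygen on an aromatic ring. Going by the values given here, none of the measured steps changes a methoxy to a hydroxy, so there is no direct guide. Among the compounds with values here, the only measured step, from compound 2 to compound 3, lies within the scatter, and compound 1, the one compound bearing a hydroxy, gives a value beyond the scatter from compound 2, though with two changes at once. A small weakening at most is therefore expected, with a step from compound 2 to compound 4 of a 1.4-fold higher number from compound 2 to compound 4 (0.14 log units; within the scatter) in this assay. Compound 4 is estimated to give 12000 nM in this assay, within a range of 5000 nM to 30000 nM.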

Compound 4, half-maximal inhibitory concentration: 940 nM
Compound 4: the middle estimate sits 13-fold (1.11 log units) above what was measured; measured number outside the range, below it.
By their numbers in this assay, from the lowest: compound 4; then compounds 2 and 3 (each within the scatter of the next); then compound 1.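

In this assay the change from methoxy to hydroxy on the aromatic ring is the first single change among these compounds to move beyond the scatter: it gives a 9.2-fold lower number from compound 2 to compound 4 (0.96 log units; beyond the scatter) while the amino group's replacement by hydrogen gave only a 1.4-fold higher number from compound 2 to compound 3 (0.14 log units; within the scatter) and so could not be told from no change. A hydroxy on this ring is not enough in itself, since swapping 3-fluoro-4-hydroxyphenyl for 3-hydroxy-4-methoxyphenyl gives a 26-fold lower number from compound 1 to compound 4 (1.42 log units; beyond the scatter) and compound 1, which also carries a hydroxy, has the highest number of the set; what counts here is the whole substitution of that ring and not merely the presence of a hydroxy. The data offered here contain nothing that accounts for the size of this step and it stands as an observation only.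

Going by these compounds, it remains open whether an ethoxy or an acetoxy group at that oxygen-bearing ring carbon would keep any of the gain, and whether the other methoxy of compound 2 behaves the same way when changed to hydroxy. Also open, on these data alone, is whether the amino group stays as unimportant with the hydroxy in place as it appeared with two methoxy groups.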